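The source may hold more compounds than are shown below. What is called first, only, known or untested is meant among the compounds shown, and "the series" means these compounds.

Measured in a functional assay on MDA-MB-231 cells (Homo sapiens), read by wound healing assay, with a stated time of 24 h; a higher number here means a weaker inhibitor, a lower number a stronger inhibitor:

- compound 1 `CC1=CC[C@H]2[C@H](CC[C@]2(C)O)C(C)(C)[C@@H]1CC[C@H]1[C@]2(C)CC[C@H](OC(=O)CCC(=O)O)C(C)(C)O[C@H]2CC[C@@]1(C)O` gives 18000 nM; 18000 nM (2 entries)
- compound 2 `CC1=CC[C@H]2[C@H](CC[C@]2(C)O)C(C)(C)[C@@H]1CC[C@H]1[C@]2(C)CC[C@H](OC(=O)c3ccccc3)C(C)(C)O[C@H]2CC[C@@]1(C)O` gives 7900 nM; 7910 nM (2 entries)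
- compound 3 `CC1=CC[C@H]2[C@H](CC[C@]2(C)O)C(C)(C)[C@@H]1CC[C@H]1[C@]2(C)CC[C@H](OC(=O)NS(=O)(=O)c3ccc(C)cc3)C(C)(C)O[C@H]2CC[C@@]1(C)O` gives 18000 nM

Compound 3 rests on a single entry (18000 nM). Among the compounds with values here, that number matches compound 1 (18000 nM; 18000 nM (2 entries)) and is higher than the one for compound 2 (7900 nM; 7910 nM (2 entries)), whose repeat entries agree closely (the several entries of compound 2 in this assay, 7900 nM; 7910 nM (2 entries)).

Compound 4 `CC1=CC[C@H]2[C@H](CC[C@]2(C)O)C(C)(C)[C@@H]1CC[C@H]1[C@]2(C)CC[C@H](OC(=O)c3ccccc3Cl)C(C)(C)O[C@H]2CC[C@@]1(C)O` is still unmeasured. It has 2-chlorophenyl in place of the ((4-methylphenyl)sulfonyl)amino of compound 3 on a carbonyl carbon (2-chlorophenyl in place of ((4-methylphenyl)sulfonyl)amino on a carbonyl carbon). Among the measured compounds, only compound 2 (7900 nM; 7910 nM (2 entries)) also carries an aromatic ring directly on that carbonyl carbon, so the expectation leans toward its number. Within the data shown here, no measured compound carries the chlorine, which leaves the range wide. In this assay a modest move toward stronger inhibition is expected, with an estimated 2.1-fold lower number from compound 3 to compound 4 (0.33 log units; beyond the scatter) as the result. Compound 4 is expected at 8500 nM with an estimated range of 3500 nM to 18000 nM in this measurement.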

Compound 4, half-maximal inhibitory concentration: 14100 nM
The estimate for compound 4 lay 1.7-fold (0.22 log units) below the measured number; measured number inside the range.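

In this assay, the swap gives a 1.3-fold lower number from compound 3 to compound 4 (0.11 log units; within the scatter), so at this carbonyl carbon the ((4-methylphenyl)sulfonyl)amino can give way to 2-chlorophenyl without a change that stands out from the scatter. Within the data shown here, this is the first sign that two quite different groups can sit here and read alike, though it rests on single entries for both compounds. Compound 4 has only one entry, 14100 nM, set against compound 2 at 7900 nM; 7910 nM (2 entries), so these numbers do not settle whether the chlorine matters, and the firmest figure in that comparison is: the several entries of compound 2 in this assay, 7900 nM; 7910 nM (2 entries)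

Still open, on these data alone, is how a fluorine or a methoxy group in place of the chlorine would read. The compounds shown also leave open what an amine or a longer alkyl chain on this carbonyl carbon would do in this assay.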